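Nitrile to Ethyl Ester at One Position of a Shared Core

The source may hold more compounds than are shown below. What is called first, only, known or untested is meant among the compounds shown, and "the series" means these compounds.

Compound 1 `CC(=O)COc1cc(=O)oc2cc(OCc3cccc(Cl)c3)ccc12` and compound 2 `N#Cc1cc(=O)oc2cc(OCc3cccc(Cl)c3)ccc12` share one core and differ only at a single aromatic carbon. In an assay on isolated protein (strain Sprague-Dawley) for inhibition of Amine oxidase [flavin-containing] A (Rattus norvegicus), read by spectrophotometry, with a stated time of 5 min, tested at 10 uM (a higher number here means more inhibition at the concentration tested (going by the name of the read-out), a lower number less inhibition), compound 1 gives 22%, and in this assay compound 2 gives 23%. The step of a number 1 percentage points higher from compound 1 to compound 2 (within the scatter) is small; the two numbers sit within the usual scatter of each other, so neither can be called stronger than the other.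

Compound 3 `CCOC(=O)c1cc(=O)oc2cc(OCc3cccc(Cl)c3)ccc12` keeps the same core and changes the same position again: ethoxycarbonyl in place of cyano on an aromatic carbon. Among the compounds with values here, the only measured step that bears on this change is the one from compound 1 to compound 2, where a different group at this carbon moved the read-out by a number 1 percentage points higher from compound 1 to compound 2 (within the scatter), which is within the scatter. With one such step as guide, no change beyond the scatter is expected here either. Compound 3 is therefore estimated at 25%, with a likely range from 8% to 45%. The expected step of a number 2 percentage points higher from compound 2 to compound 3 (within the scatter) is thus essentially flat.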

Compound 3, a percentage reported as inhibition, at one concentration (the size of the read-out at that concentration, not a potency): 4.4%
The estimate for compound 3 lay 20.6 percentage points above the measured number; the whole stated range lies above it.
By their numbers in this assay, from the lowest: compound 3; then compounds 1 and 2 (each within the scatter of the next).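

The earlier pair showed two different groups at this aromatic carbon giving readings within the scatter of each other, which could have meant that the group there hardly matters. Compound 3 shows that it can matter: in this assay, putting ethoxycarbonyl in place of cyano gives a number 18.6 percentage points lower from compound 2 to compound 3 (beyond the scatter) and the comparison with the 2-oxopropoxy group gives a number 17.6 percentage points lower from compound 1 to compound 3 (beyond the scatter) so compound 3 reads lowest of the three, while the other two remain level. Nothing measured on these compounds gives a reason for this drop.

Three groups at one carbon of one core cannot show which part of the ethoxycarbonyl group goes with the lower number, the carbonyl linked to the ring or the ethyl end beyond it. A carboxylic acid, a methyl ester or a primary amide at the same carbon would separate these two parts, and a longer ester chain would show whether the reading keeps falling as the chain grows.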